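A few compounds are considered here, and "the series" means these few. Any claim that something is new, unique, unknown or untested is made for them only; others in the source may bear on it.

Compound 1, `Cc1cccc(C2(CNC(=O)Nc3c(C(C)C)cccc3C(C)C)CCCC2)c1`: 15 nM
Compound 2, `CC(C)c1cccc(C(C)C)c1NC(=O)NCC1(c2cccc(N)c2)CCCC1`: 21 nM
Compound 3, `CC(C)c1cccc(C(C)C)c1NC(=O)NCC1(c2ccc(N)cc2)CCCC1`: 29 nM

All three were tested in an assay on microsomes for inhibition of acyl-CoA:cholesterol acyltransferase (Oryctolagus cuniculus); a higher number here means a weaker inhibitor, a lower number a stronger inhibitor. Among the compounds with values here, of the three numbers, the one for compound 1 is the lowest, but the gap to compound 2 is a 1.4-fold higher number from compound 1 to compound 2 (0.15 log units; within the scatter) and the gap to compound 3 is a 1.9-fold higher number from compound 1 to compound 3 (0.29 log units; within the scatter); both fall within the scatter, so the three cannot be told apart on these data.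

Compound 4, `CC(C)c1cccc(C(C)C)c1NC(=O)NCC1(c2cccc(N(C)C)c2)CCCC1`, differs from compound 1 in one place: dimethylamino in place of methyl on an aromatic carbon. The closest measured comparison is the step in which an amino group took the same position on the same ring, a 1.4-fold higher number from compound 1 to compound 2 (0.15 log units; within the scatter). Shifting the amino group to the other ring position, a 1.4-fold higher number from compound 2 to compound 3 (0.14 log units; within the scatter), and the combined change from compound 1 to compound 3, a 1.9-fold higher number from compound 1 to compound 3 (0.29 log units; within the scatter), also stayed within the scatter. Substitution at this aromatic carbon has so far left this assay essentially unchanged, and there is no measured example of a dimethylamino group to suggest otherwise.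

A step no larger than the scatter is therefore expected, with no clear direction, so for compound 4 the expected step is a 1.3-fold higher number from compound 1 to compound 4 (0.12 log units; within the scatter). The estimate for compound 4 is 20 nM, with an expected range from 8 nM to 50 nM.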

Compound 4, half-maximal inhibitory concentration: 33 nM
For compound 4 the middle estimate is 1.7-fold (0.22 log units) below the measured one; the measured number falls inside the stated range.
By their numbers in this assay, from the lowest: compounds 1, 2, 3 and 4 (each within the scatter of the next, the first and the last beyond it).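

In this assay the change from methyl to dimethylamino on this aromatic carbon is the first single change among these compounds to pass beyond the usual scatter, with a 2.2-fold higher number from compound 1 to compound 4 (0.34 log units; beyond the scatter) as a modest step. The position therefore accepts this larger group at only a small cost, and the cost shows up only against the methyl compound. Set against the two compounds with a free amino group, the new compound cannot be told apart: a 1.6-fold higher number from compound 2 to compound 4 (0.20 log units; within the scatter) for dimethylamino in place of amino, and a 1.1-fold higher number from compound 3 to compound 4 (0.06 log units; within the scatter) for the change of the whole aryl group, so the two methyl groups on the nitrogen make no readable difference by themselves. Nothing among the data shown explains why the step from the methyl compound arose.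

On these data alone, what stays open is whether that step follows the nitrogen or simply the larger group of three heavy atoms, since no all-carbon group of that size, such as isopropyl, stands at this carbon. A methylamino group or a methoxy group at the same place would also show whether the trend from amino to dimethylamino holds at all, or whether a single modest step is all there is.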